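The source may report more compounds than this note shows. Statements on the series, on what has been measured and on what is new or still open speak of the compounds shown alone.

Of the compounds shown here, three sharing one core have been measured in an assay on HEK293 cells for inhibition of Voltage-dependent T-type calcium channel subunit alpha-1G (Homo sapiens), read by fluorescence, tested at 10 uM; on this read-out higher numbers stand for more inhibition at the one concentration tested (going by the name of the read-out) and lower numbers for less inhibition. Compound 1 `CCCc1nc(-c2ccccc2)c(CNCCCN2CCN(c3cccc(F)c3)CC2)o1` gives 68.9%, compound 2 `CCCc1nc(-c2ccccc2)c(CNCCCN2CCN(c3cccc(C)c3)CC2)o1` gives 47.8%, and compound 3 `CCCc1nc(-c2ccccc2)c(CNCCCN2CCN(c3ccccc3F)CC2)o1` gives 54.4%. Compound 3 thus stands second highest of the three: its nearest neighbour is compound 2, which lies within the scatter of it, as a number 6.6 percentage points higher from compound 2 to compound 3 (within the scatter) shows, while compound 1 lies beyond the scatter, as a number 14.5 percentage points lower from compound 1 to compound 3 (beyond the scatter) shows.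

Compound 4 `CCCc1nc(-c2ccccc2)c(CNCCCN2CCN(c3ccccc3C)CC2)o1` has not been measured. It differs from compound 3 in one place: methyl in place of fluoro on an aromatic carbon, on an aromatic carbon of a six-membered aromatic ring of carbon only, ortho to a large group. Going by the values given here, the one measured step that bears on it is the same exchange at another position of the ring, a number 21.1 percentage points lower from compound 1 to compound 2 (beyond the scatter), a modest drop that went beyond the scatter. Whether the ortho position behaves the same is not known from these three compounds, so the expectation rests on that single step and carries a wide range.

On that basis compound 4 is expected to show a drop of a number 14.4 percentage points lower from compound 3 to compound 4 (beyond the scatter) in this assay. The estimate for compound 4 is 40%, with a range from 25% to 55%.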

Compound 4, a percentage reported as inhibition, at one concentration (the size of the read-out at that concentration, not a potency): 54.5%
Estimate against measurement, compound 4: 14.5 percentage points below, and the stated range covers the measured number.
By their numbers in this assay, from the lowest: compounds 2, 3 and 4 (each within the scatter of the next); then compound 1.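

In this assay, methyl in place of fluoro on an aromatic carbon ortho to a large group gives a number 0.1 percentage points higher from compound 3 to compound 4 (within the scatter), so the drop this exchange produced in the earlier pair does not reappear in the pair 2-fluorophenyl to 2-methylphenyl. With methyl on the ring in both compounds, the 2-methylphenyl group in place of the 3-methylphenyl group gives a number 6.7 percentage points higher from compound 2 to compound 4 (within the scatter), which means that only the 3-fluorophenyl group stands apart among these four, with a number 14.4 percentage points lower from compound 1 to compound 4 (beyond the scatter). The same exchange therefore has a size that depends on where it sits on the ring, the two steps differing by more than the scatter allows: the same change on two cores in this assay, a number 21.1 percentage points lower (beyond the scatter) from compound 1 to compound 2 and a number 0.1 percentage points higher (within the scatter) from compound 3 to compound 4, 21.2 percentage points apart, beyond the scatter of two such steps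

A chloro, methoxy or nitrile group at either place on that ring could show whether the higher reading of compound 1 belongs to fluoro itself or to any group at that place. From the compounds shown here alone, it also remains open whether these differences would hold at other concentrations, and whether they would survive with a longer chain in place of the propyl group on the shared core.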